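Adding a second chlorine to a benzylpurine scaffold

The source may hold more compounds than are shown below. What is called first, only, known or untested is meant among the compounds shown, and "the series" means these compounds.

Compound 1 `ClCc1cccc(Cn2cnc3c(Cl)ncnc32)c1` was examined in a functional assay on UACC-257 cells (Homo sapiens) for cytotoxicity, read by sulforhodamine B assay, with a stated time of 48 h (on this read-out higher numbers stand for weaker inhibition of growth and lower numbers for stronger inhibition of growth), where compound 1 gives 37200 nM. Of the two compounds measured, compound 1 has the higher number; compound 2 `ClCc1ccc(Cn2cnc3nc(Cl)nc(Cl)c32)cc1`, the nearest one, gives 5490 nM in this assay, and the gap between the two is beyond the scatter. Compound 3 `ClCc1cccc(Cn2cnc3c(Cl)nc(Cl)nc32)c1` has not yet been measured in this assay. It differs from compound 1 in one place: chloro in place of hydrogen on an aromatic carbon, between two ring nitrogen atoms and meta to the existing chloro group. Among the compounds with values here, no measured pair isolates this change. Within the data shown here, because the only other measured compound, compound 2, carries two chlorines on the same core and gives 5490 nM, a step toward stronger inhibition of growth is expected, of a size beyond the scatter, as a 3.7-fold lower number from compound 1 to compound 3 (0.57 log units; beyond the scatter). On that basis compound 3 is estimated to give 10000 nM in this assay, within 4000 nM to 30000 nM.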

Compound 3, concentration for total growth inhibition: 3460 nM
Beside the measured number, compound 3's estimate is 2.9-fold (0.46 log units) above it, outside the stated range (below it).
By their numbers in this assay, from the lowest: compounds 3 and 2 (each within the scatter of the next); then compound 1.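

In this assay, chloro in place of hydrogen on an aromatic carbon between two ring nitrogen atoms gives an 11-fold lower number from compound 1 to compound 3 (1.03 log units; beyond the scatter), a large step beyond the scatter. Within the data shown here, this pair is the first to isolate the change, and it shows that this single position on the shared core strongly affects inhibition of growth, with the rest of the structure left unchanged. Nothing given here explains why the step is this large.

Going by these compounds, it remains open whether an amine, a methoxy group or a fluoro group at the same position would shift the number in the same direction or by a similar amount. On these data alone, it also remains open whether the step from hydrogen to chloro would carry over to other cell lines.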